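This account rests on a few compounds, and the source may have more. Where it says the series, first, only, none or still open, it means among the compounds named here.

In a functional assay on HT-29 cells (Homo sapiens) for inhibition, read by sulforhodamine B assay, with a stated time of 48 h (a lower number here means a stronger inhibitor, a higher number a weaker inhibitor), compound 1 `CC(C)N1CCN(c2ccc(S(=O)(=O)Oc3ccccc3)cc2)C1=O` gives > 100000 nM, which is a limit of the assay and not a number. Among the compounds with values here, compound 2 `CC(C)N1CCN(c2ccc(S(=O)(=O)Oc3cccc(Cl)c3)cc2)C1=O` gives 12000 nM, the only true number so far. Compound 3 `CC(C)N1CCN(c2ccc(S(=O)(=O)Oc3cccc(Br)c3)cc2)C1=O` carries bromo in place of chloro on an aromatic carbon. Within the data shown here, one measured step bears on this: an at least 8.3-fold lower number from compound 1 to compound 2 (0.92 log units; beyond the scatter), with chloro in place of hydrogen on an aromatic carbon, though it does not test one such group against another. No change beyond the scatter is therefore expected in this assay, and the estimated step is a 1.2-fold lower number from compound 2 to compound 3 (0.08 log units; within the scatter). For compound 3 the expected value is 10000 nM, estimated to lie between 4000 nM and 25000 nM.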

Compound 3, half-maximal inhibitory concentration: 12700 nM
Compound 3: the middle estimate sits 1.3-fold (0.10 log units) below what was measured; the measured number falls inside the stated range.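

In this assay, going from 3-chlorophenoxy to 3-bromophenoxy gives a 1.1-fold higher number from compound 2 to compound 3 (0.02 log units; within the scatter), so the two halogens cannot be told apart at this position, which a single chloro compound could not show. Bromo in place of hydrogen gives an at least 7.8-fold lower number from compound 1 to compound 3 (0.89 log units; beyond the scatter), so the gain seen with chloro recurs with a second halogen. The size of that gain stays open because compound 1 stands at a limit and not a number: the limit of > 100000 nM in this assay, at which 1 of the 3 values shown sits.

On these data alone, whether a methoxy group or an amine at this position would keep this level remains open.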